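The source may hold more compounds than are shown below. What is called first, only, known or untested is meant among the compounds shown, and "the series" means these compounds.

Measured compounds:
compound 1 `N/C(=N\NC(=S)N1CCOCC1)c1ccccn1`, 56.3%
compound 2 `Cc1ccnc(/C(N)=N/NC(=S)N2CCOCC2)c1`, 49.1%
compound 3 `Cc1cccc(/C(N)=N/NC(=S)N2CCOCC2)n1`, 85.4%

All three were tested in a functional assay on HeLa cells (Homo sapiens) for cytotoxicity, read by MTT assay, with a stated time of 72 h, tested at 10 uM; on this read-out higher numbers stand for more inhibition of growth at the one concentration tested and lower numbers for less inhibition of growth. Compound 1 stands second highest of the three numbers. Its nearest neighbour is compound 2, and the step of a number 7.2 percentage points lower from compound 1 to compound 2 (within the scatter) lies within the scatter, so no order between these two can be read. The step of a number 29.1 percentage points higher from compound 1 to compound 3 (beyond the scatter) is beyond the scatter and modest in size.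

Compound 4 `N/C(=N\NC(=S)N1CCCC1)c1ccccn1` is not yet measured. It differs from compound 1 in one place: pyrrolidin-1-yl in place of morpholin-4-yl on a thiocarbonyl carbon. Neither measured step bears on this change, since both steps concern a methyl in place of hydrogen on an aromatic carbon, while the change to compound 4 sits on the thiocarbonyl carbon and exchanges one saturated ring for another. The shown compounds therefore give no guide to the direction or size of the effect of this exchange in this assay.

For the measured compounds named here, with no step at this position to lean on, the expected value for compound 4 is taken close to that of compound 1: the estimated step is a number 1.3 percentage points lower from compound 1 to compound 4 (within the scatter), and compound 4 is expected to give 55%, with a range from 30% to 80%.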

Compound 4, percent growth inhibition at one concentration: 63.5%
The estimate for compound 4 lay 8.5 percentage points below the measured number; the range from low to high includes it.
By their numbers in this assay, from the lowest: compounds 2, 1 and 4 (each within the scatter of the next, the first and the last beyond it); then compound 3.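

In this assay, for the compounds shown here, the exchange of morpholin-4-yl for pyrrolidin-1-yl on the thiocarbonyl carbon gives the first reading at this position: a number 7.2 percentage points higher from compound 1 to compound 4 (within the scatter). The ring oxygen and its hydrogen-bond acceptor leave with this exchange and the ring goes from six-membered to five-membered, yet no order between the two compounds can be read, so among the compounds shown this position takes either ring without a difference beyond the scatter, while the one step beyond it remains a number 29.1 percentage points higher from compound 1 to compound 3 (beyond the scatter) on an aromatic carbon. Nothing shown offers an explanation for these readings at the thiocarbonyl carbon.

The compounds shown leave open how other groups on the thiocarbonyl carbon would read, such as piperidin-1-yl, 4-methylpiperazin-1-yl or an open-chain dimethylamino group, any of which would show whether this position stays as undemanding beyond these two rings. They also leave open whether pyrrolidin-1-yl would read the same alongside the methyl group of compound 3, since the two changes are not seen together in one compound.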